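The source may hold more compounds than are shown below. What is called first, only, known or untested is meant among the compounds shown, and "the series" means these compounds.

Compound 1 `COc1ccc(-c2cc(-c3cccc(S(C)(=O)=O)c3)cnc2N)cn1`: 25 ug/mL
Compound 2 `COc1ccc(-c2cc(-c3ccc(S(N)(=O)=O)cc3)cnc2N)cn1`: 12.5 ug/mL

Of the compounds shown here, two have so far been measured in a physicochemical assay for solubility, read by nephelometry, in phosphate buffer, measured as kinetic solubility, at pH 6.5; a higher number here means a more soluble compound, a lower number a less soluble compound. Compound 2 stands at the bottom of these two numbers, with compound 1 as its only neighbour; the distance between the two lies within the usual scatter of this assay, so no real difference between compound 1 and compound 2 can be claimed from what is shown.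

Compound 3 `COc1ccc(-c2cc(-c3ccc(C(=O)O)cc3)cnc2N)cn1` has not yet been measured. It differs from compound 2 in one place: carboxy in place of sulfamoyl on an aromatic carbon. Among the compounds with values here, no pair of measured compounds shows a change of this kind, so there is no measured step to lean on, and the expectation rests on the change itself. A moderate rise is expected, a step of a 2.4-fold higher number from compound 2 to compound 3 (0.38 log units; beyond the scatter), and compound 3 is estimated to give about 30 ug/mL in this assay, with a range from 10 ug/mL to 90 ug/mL.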

Compound 3, solubility: 6.3 ug/mL
Estimate against measurement, compound 3: 4.8-fold (0.68 log units) above; the measured number lies below the stated range.
By their numbers in this assay, from the lowest: compounds 3, 2 and 1 (each within the scatter of the next, the first and the last beyond it).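

Within the data shown here, this is the first measured look at the position para to a large group, on the aromatic carbon that carries sulfamoyl in compound 2. Carboxy in place of sulfamoyl there gives a 2.0-fold lower number from compound 2 to compound 3 (0.30 log units; within the scatter) in this assay, so this exchange, with one heavy atom fewer in the entering group and the same count of hydrogen-bond donors, separates compound 2 and compound 3 by no real difference. No measurement shown here bears on why the two groups read alike.

On these data alone, whether an amine, a carboxamide or a hydroxymethyl group on the same carbon would stand apart from sulfamoyl and carboxy in this assay remains open. So does the effect of the place of the substituent on its own, since compound 1 differs from compound 2 in more than one place.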